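The source may hold more compounds than are shown below. What is called first, only, known or untested is meant among the compounds shown, and "the series" means these compounds.

Measured compounds in a functional assay on PC-3 cells (Homo sapiens) for cytotoxicity, read by MTT assay, with a stated time of 72 h; a higher number here means a weaker inhibitor of growth, a lower number a stronger inhibitor of growth:
Compound 1, `COc1ccc(OC(=O)Nc2ccc([Se]C#N)cc2)cc1`, gives 7500 nM.
Compound 2, `N#C[Se]c1ccc(NC(=O)OCc2ccc([N+](=O)[O-])cc2)cc1`, gives 9000 nM.

Compound 1 holds the lowest of the two numbers recorded in this assay, with compound 2 the nearest to it, and the gap between the two falls within the usual scatter of repeated measurements, so the two compounds cannot be told apart by their values. Both are carbamates built on a shared core that carries the selenocyanate group, and they differ from each other in the ester side of the carbamate.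

Compound 3, `N#C[Se]c1ccc(NC(=O)Oc2ccc(Cl)cc2)cc1`, has not yet been measured in this assay. It is derived from compound 1 by a single change: chloro in place of methoxy on an aromatic carbon. For the measured compounds named here, no step between measured compounds in this assay covers an exchange of this kind, so nothing in the data says how the value should move. Going by the values given here, with only two measured values and both close together, compound 3 is expected to stay in the same region, and the step of a 1.2-fold lower number from compound 1 to compound 3 (0.06 log units; within the scatter) is estimated to be no larger than the scatter, in either direction. On that basis compound 3 is estimated to give 6500 nM, within a range from 2500 nM to 16000 nM.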

Compound 3, concentration for 50% growth inhibition: 6400 nM
For compound 3 the middle estimate is 1.0-fold (0.01 log units) above the measured one, within the range that was stated.
By their numbers in this assay, from the lowest: compounds 3, 1 and 2 (each within the scatter of the next).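

In this assay, for the compounds shown here, the exchange of methoxy for chloro on an aromatic carbon, para to a large group, gives a 1.2-fold lower number from compound 1 to compound 3 (0.07 log units; within the scatter) and is the first step at this position that can be read, since the earlier compounds offered no step at all. At this position, then, a group of two heavy atoms with one hydrogen-bond acceptor gives way to a single chlorine with none, and compound 1 and compound 3 still cannot be told apart by their values, so this one exchange on the shared core leaves the growth-inhibition reading unresolved from the scatter. The data hold no measurement that bears on why this exchange leaves the two values so close.

The compounds shown leave open whether another kind of group on this same aromatic carbon, such as an amine or a carboxylic acid, would move the number beyond the scatter. Equally open, on these data alone, is how the number would respond to a thiocyanate in place of the selenocyanate on the shared core.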